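An Enlarged Aromatic Group on Compound 2

The source may report more compounds than this note shows. Statements on the series, on what has been measured and on what is new or still open speak of the compounds shown alone.

In an ADME assay on the whole organism (Mus musculus, strain CD-1) for pharmacokinetics, at a dose of 10 mg/kg by the oral route (a lower number here means that a smaller share of the oral dose reaches the circulation, a higher number that a larger share of the oral dose reaches the circulation), compound 1 `COc1cc([C@](O)(CCN(C)C)[C@@H](c2cc3cc(Br)ccc3nc2OC)c2cccc(OC)c2F)cc(OC(F)F)n1` gives 83% and compound 2 `COc1cccc([C@H](c2cc3cc(Br)ccc3nc2OC)[C@@](O)(CCN(C)C)c2cc(SC)nc(SC)c2)c1F` gives 66% as the lower of the two numbers. Compound 3 `CCSc1cc([C@](O)(CCN(C)C)[C@@H](c2cc3cc(Br)ccc3nc2OC)c2cccc(OC)c2F)cc(SCC)n1` differs from compound 2 in one place, where a group of 12 heavy atoms (9 carbon, 1 nitrogen, 2 sulfur; one six-membered aromatic ring with 1 hetero atom) in place of a group of 10 heavy atoms (7 carbon, 1 nitrogen, 2 sulfur; one six-membered aromatic ring with 1 hetero atom), on a saturated chain carbon bound to an oxygen on a saturated carbon and two saturated chain carbons is the whole change. Among the compounds with values here, the only measured step at that place is a number 17 percentage points lower from compound 1 to compound 2 (beyond the scatter) and it exchanged different groups, so it guides the expectation only loosely. A smaller downward move is expected, with a number 6 percentage points lower from compound 2 to compound 3 (within the scatter) as the estimated step for this change. The expected value for compound 3 is 60% within an estimated range of 42% to 76% in this measurement.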

Compound 3, oral bioavailability: 25%
The estimate for compound 3 lay 35 percentage points above the measured number; measured number below the stated range.
By their numbers in this assay, from the lowest: compound 3; then compound 2; then compound 1.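

In this assay, this position proves more sensitive than the earlier step showed: the group of 12 heavy atoms in place of the group of 10 heavy atoms, with the same ring and the same hydrogen-bond counts, gives a number 41 percentage points lower from compound 2 to compound 3 (beyond the scatter). Measured against the group bearing oxygen and fluorine, the drop is wider still, with a number 58 percentage points lower from compound 1 to compound 3 (beyond the scatter). Nothing available explains why the number falls. The compounds shown leave open how a longer chain, such as propylthio on the same ring, would read here, and whether an amine in its place would raise the number.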